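Adding Bromine to Compound 3: What to Expect

The compounds below may be only part of what the source reports. "The series", "measured", "known", "first", "only" and "open" are said of these compounds alone.

Measured compounds and their readings:
compound 1, `CCOc1ccc2nc(Cl)c(/C=N/NC(=O)c3cc4ccc(O)cc4oc3=O)cc2c1`: 17100 nM
compound 2, `CCOc1ccc(NC(=O)c2cc3cc([N+](=O)[O-])ccc3oc2=O)cc1`: 13200 nM
compound 3, `Cc1noc(NS(=O)(=O)c2ccc(NC(=O)c3cc4ccccc4oc3=O)cc2)c1C`: 26600 nM

All three were tested in a functional assay on CCRF-CEM cells (Homo sapiens) for antiproliferative activity, read by fluorescence and resazurin assay, with a stated time of 48 h; a lower number here means a stronger inhibitor, a higher number a weaker inhibitor. Within that set, compound 3 gives the numerically highest reading, yet the other two are not far off: compound 1 is nearest and compound 2 furthest, and both differences sit within the usual scatter of repeated measurements. No ranking among the three can therefore be claimed, and none of them can be called stronger or weaker than the others on this evidence.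

Compound 4, `Cc1noc(NS(=O)(=O)c2ccc(NC(=O)c3cc4cc(Br)ccc4oc3=O)cc2)c1C`, keeps the whole of compound 3 and adds one atom. The change is bromo in place of hydrogen on an aromatic carbon. Compound 2 also carries a group on the fused two-ring core, but it differs from compound 3 in other parts as well, so its value says nothing direct about what a bromine on this position does.

Among the compounds with values here, with no measured pair showing this exact change, the expectation is a step of a 1.4-fold lower number from compound 3 to compound 4 (0.15 log units; within the scatter), that is, nothing clearly beyond the scatter. Compound 4 is estimated at 19000 nM, with a range from 7000 nM to 50000 nM.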

Compound 4, half-maximal inhibitory concentration: 14600 nM
The estimate for compound 4 lay 1.3-fold (0.11 log units) above the measured number; low and high end bracket the measured number.
By their numbers in this assay, from the lowest: compounds 2, 4, 1 and 3 (each within the scatter of the next).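

Within the data shown here, compound 3 and compound 4 form the first pair here that differs in only one place. In this assay the change gives a 1.8-fold lower number from compound 3 to compound 4 (0.26 log units; within the scatter) and thus offers a direct reading of what bromo in place of hydrogen does on this aromatic carbon of the fused two-ring system. The bromine atom can sit here without taking the reading clearly away from that of compound 3, so neither a gain nor a loss in antiproliferative activity can be claimed for it. Nothing in the data shown speaks to what lies behind this reading.

As far as these compounds go, this is a single change at a single position, so it remains open whether fluoro, an amine or a carboxylic acid on the same carbon would also stay within the scatter or would produce a clear step in either direction. From the compounds shown here alone, it is equally open whether bromo on another carbon of the same ring would behave as it does here.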